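The compounds below may be only part of what the source reports. "The series", "measured", "known", "first", "only" and "open" are said of these compounds alone.

In a functional assay on A549 cells (Homo sapiens) for antiproliferative activity, read by MTT assay, with a stated time of 48 h (a higher number here means a weaker inhibitor of growth, a lower number a stronger inhibitor of growth), compound 1 (`COC(=O)N1N=C(c2cccc(OC)c2)CC1c1cc(OC)c(OC)c(OC)c1`) gives 2590 nM, while compound 2 (`COC(=O)N1N=C(c2ccc(O)cc2)CC1c1cc(OC)c(OC)c(OC)c1`) gives 8570 nM, the higher of the two numbers and so the weaker growth inhibition. Compound 3 (`COC(=O)N1N=C(c2ccc(OC)c(OC)c2)CC1c1cc(OC)c(OC)c(OC)c1`) has not yet been measured. It carries 3,4-dimethoxyphenyl in place of 4-hydroxyphenyl on a carbon with a double bond to nitrogen. For the measured compounds named here, only one measured step bears on this change, a 3.3-fold higher number from compound 1 to compound 2 (0.52 log units; beyond the scatter), where 4-hydroxyphenyl replaced 3-methoxyphenyl at that same place. That step is modest but beyond the scatter. Read in reverse, it suggests a modest move toward a lower number in this assay, landing close to compound 1 at 2590 nM. The expected change is a 2.9-fold lower number from compound 2 to compound 3 (0.46 log units; beyond the scatter). For compound 3 the estimated value is 3000 nM, with an expected range from 1100 nM to 8000 nM.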

Compound 3, concentration for 50% growth inhibition: 3930 nM
Beside the measured number, compound 3's estimate is 1.3-fold (0.12 log units) below it, and the stated range covers the measured number.
By their numbers in this assay, from the lowest: compounds 1 and 3 (each within the scatter of the next); then compound 2.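

In this assay the swap of 4-hydroxyphenyl for 3,4-dimethoxyphenyl gives a 2.2-fold lower number from compound 2 to compound 3 (0.34 log units; beyond the scatter) and so shows that a second aryl group carrying methoxy groups at this place also reads lower than the 4-hydroxyphenyl of compound 2. Methoxy in place of hydrogen on an aromatic carbon gives a 1.5-fold higher number from compound 1 to compound 3 (0.18 log units; within the scatter) and so separates the one-methoxy and two-methoxy aryl groups by no more than the scatter. Nothing shown gives a reason for these differences.

Still open, going by these compounds, is whether the hydroxy group itself or its location sets compound 2 apart, a question that 4-methoxyphenyl and 3-hydroxyphenyl would address. The compounds shown also say nothing about an aminophenyl or a carboxyphenyl group at this place.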